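Aryl sulfone series: methoxy to hydroxy at compound 4

The source may hold more compounds than are shown below. What is called first, only, known or untested is meant among the compounds shown, and "the series" means these compounds.

compound 1 `CSc1nn2cccnc2c1S(=O)(=O)c1ccccc1`: 115 nM
compound 2 `CNc1nn2c(C)cc(C)nc2c1S(=O)(=O)c1ccc(F)cc1`: 0.398 nM
compound 3 `CNc1nn2c(C)cc(C)nc2c1S(=O)(=O)c1ccc(OC)cc1`: 9.55 nM

In a functional assay on HEK293 cells for antagonist activity at 5-hydroxytryptamine receptor 6 (Homo sapiens), read by cAMP accumulation, with a stated time of 2 h (a higher number here means a weaker inhibitor, a lower number a stronger inhibitor), compound 3 gives 9.55 nM, the second highest of the three numbers; compound 1 gives 115 nM and compound 2 gives 0.398 nM. Compound 4 `CNc1nn2c(C)cc(C)nc2c1S(=O)(=O)c1ccc(O)cc1` differs from compound 3 by hydrogen in place of methyl on an oxygen on an aromatic ring. Going by the values given here, the only measured step at the same place is a 24-fold higher number from compound 2 to compound 3 (1.38 log units; beyond the scatter), where fluoro gave way to methoxy. Among the compounds with values here, the present change removes the methyl of that methoxy and leaves hydroxy; no measured pair sets methoxy directly against hydroxy. A partial return toward the number of compound 2 is expected rather than the whole way, so for compound 4 a step of a 2.4-fold lower number from compound 3 to compound 4 (0.38 log units; beyond the scatter) is expected, with an estimate of 4 nM and a range from 1 nM to 15 nM.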

Compound 4, inhibition constant: 2 nM
Compound 4: middle estimate off by 2.0-fold (0.30 log units), on the high side, within the range that was stated.
By their numbers in this assay, from the lowest: compound 2; then compound 4; then compound 3; then compound 1.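

Removing the methyl from the oxygen gives a 4.8-fold lower number from compound 3 to compound 4 (0.68 log units; beyond the scatter) and so recovers part of the loss seen with methoxy, while the switch from fluoro to hydroxy still leaves a 5.0-fold higher number from compound 2 to compound 4 (0.70 log units; beyond the scatter) in this series. The oxygen on the aromatic ring therefore does not set the number alone, since the methyl on it matters as well. Nothing available explains either step.

As far as these compounds go, whether chloro, an amine or ethoxy at this place would fall inside the span from fluoro to methoxy stays open.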